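The source may report more compounds than this note shows. Statements on the series, on what has been measured and on what is new or still open speak of the compounds shown alone.

In a functional assay on MCF7 cells (Homo sapiens) for cytotoxicity, read by MTT assay, with a stated time of 6 days (on this read-out lower numbers stand for an effect already at smaller amounts and higher numbers for an effect only at larger amounts of compound), compound 1 (`COC(=O)c1c(-c2ccc(OC)cc2)oc2ccccc2c1=O`) gives > 25 ug/mL, which is a limit of the assay and not a number. Compound 2 (`COC(=O)c1c(-c2ccc([N+](=O)[O-])cc2)oc2ccccc2c1=O`) gives > 25 ug/mL, again a limit and not a number. Compound 2 therefore has no exact position, and the data offer only (the limit of > 25 ug/mL in this assay, at which 2 of the 2 values shown sit). Compound 3 (`COC(=O)c1c(-c2ccc([N+](=O)[O-])cc2)oc2cc(OC)ccc2c1=O`) keeps the nitro group of compound 2 and gains a methoxy on the shared core: methoxy in place of hydrogen on an aromatic carbon. Going by the values given here, the one measured change, nitro in place of methoxy on an aromatic carbon, is a step that the two limits leave unreadable from compound 1 to compound 2, so it offers no size to carry over. Nothing measured points to a step beyond the scatter in this assay, in either direction. The expected change is a step that the limit leaves unreadable from compound 2 to compound 3. The estimate for compound 3 is 30 ug/mL, with an expected range from 12 ug/mL to 60 ug/mL.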

Compound 3, concentration for half-maximal effect: > 25 ug/mL
Compound 3: only a limit was reported (the forecaster's own chance of this, stated with the estimate: 70%); the middle value is on the limit's open side.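

Compound 3, like compound 2, gives a limit and not a number, so no step between them can be read: the limit of > 25 ug/mL in this assay, at which 3 of the 3 values shown sit.

The compounds shown leave open how much compound would be needed for half-maximal effect, and whether swapping methoxy for hydrogen changes that amount at all.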